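The source may hold more compounds than are shown below. What is called first, only, known or untested is meant among the compounds shown, and "the series" means these compounds.

Measured in a functional assay on OVCAR-8 cells (Homo sapiens) for inhibition, read by sulforhodamine B assay, with a stated time of 48 h (on this read-out lower numbers stand for stronger inhibition of growth and higher numbers for weaker inhibition of growth), so far:

compound 1 `O=C(Nc1cccc(-n2cc(-c3ccncc3)c(-c3ccc(Cl)c(O)c3)n2)c1)Nc1cccc(C(F)(F)F)c1` — compound 1 gives 1570 nM
compound 2 `COc1cc(-c2nn(-c3cccc(NC(=O)Nc4cc(C(F)(F)F)cc(C(F)(F)F)c4)c3)cc2-c2ccncc2)ccc1Cl` — compound 2 gives 524 nM
compound 3 `COc1cc(-c2nn(-c3cccc(NC(=O)c4cccc(C(F)(F)F)c4)c3)cc2-c2ccncc2)ccc1Cl` — compound 3 gives 2000 nM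

Compound 3 stands at the highest of the three numbers. Its nearest neighbour is compound 1, whose number lies within the scatter of compound 3, so nothing separates the two. Compound 2, the only urea on the same core as compound 3, has a number well beyond the scatter below it; compound 2 and compound 3 differ in more than one place, so their two values alone show that the urea with the bis(trifluoromethyl)phenyl group reads lower than the amide.

Compound 4 `COc1cc(-c2nn(-c3cccc(NC(=O)Nc4ccc(Cl)c(Cl)c4)c3)cc2-c2ccncc2)ccc1Cl` is not yet measured in this assay. It differs from compound 3 by (3,4-dichlorophenyl)amino in place of 3-(trifluoromethyl)phenyl on a carbonyl carbon. Compound 4 is thus the urea analogue of compound 3 on the same core, carrying a dichlorinated ring instead of a trifluoromethyl one. The step from compound 3 to compound 4 is expected to lower the number, by a size beyond the scatter but not by the full gap that compound 2 shows against compound 3, since the pair of compound 2 and compound 3 combines two changes. The expected step is a 2.5-fold lower number from compound 3 to compound 4 (0.40 log units; beyond the scatter). Compound 4 is estimated at 800 nM, with a range from 300 nM to 2500 nM.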

Compound 4, concentration for 50% growth inhibition: 931 nM
Compound 4: middle estimate off by 1.2-fold (0.07 log units), on the low side, within the range that was stated.
By their numbers in this assay, from the lowest: compounds 2, 4, 1 and 3 (each within the scatter of the next, the first and the last beyond it).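

In this assay, within the data shown here, a 2.1-fold lower number from compound 3 to compound 4 (0.33 log units; beyond the scatter) is the first step read at this position on the shared core, and it shows that a modest lowering comes with (3,4-dichlorophenyl)amino in place of 3-(trifluoromethyl)phenyl on a carbonyl carbon. This single step carries two differences at once, since the entering group adds a nitrogen with one hydrogen-bond donor to the link and also exchanges the trifluoromethyl group for two chlorines on the ring, so it cannot assign the lowering to the link or to the ring substituents. Nothing measured on these compounds accounts for the step.

Still open, going by these compounds, is how the two differences separate, which would take the amide carrying the 3,4-dichlorophenyl ring and the urea carrying the 3-(trifluoromethyl)phenyl ring on this same core. Also open, on these data alone, is whether the ring on the carbonyl carbon is needed at all, for example whether a plain alkyl chain, a dimethylamino group or a carboxylic acid at that place keeps the growth inhibition.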